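The source may report more compounds than this note shows. Statements on the series, on what has been measured and on what is new or still open speak of the compounds shown alone.

Measured in a functional assay on NCI-H520 cells (Homo sapiens) for cytotoxicity; a higher number here means a weaker inhibitor of growth, a lower number a stronger inhibitor of growth:
- Compound 1 `COc1ccc(C2=C(c3ccc(SC)cc3)CC3CCCN3C2=O)cc1C`: 100 nM
- Compound 2 `CSc1ccc(C2=C(c3ccc(F)c(F)c3)C(=O)N3CCCC3C2)cc1`: 200 nM
- Compound 3 `COc1ccc(C2=C(c3ccc(SC)cc3)CC3CCCN3C2=O)cc1OC`: 2000 nM

Compound 3, at 2000 nM, has the highest number of the three and is therefore the weakest inhibitor of growth in this set. Compound 4 `COc1ccc(C2=C(c3ccc(SC)cc3)CC3CCCN3C2=O)cc1` has hydrogen in place of methoxy on an aromatic carbon, ortho to a methoxy group and meta to a large group (hydrogen in place of methoxy on an aromatic carbon).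

Among the compounds with values here, two measured steps bear on this change. The closer one is large: a 20-fold higher number from compound 1 to compound 3 (1.30 log units; beyond the scatter), with methoxy in place of methyl on the same aromatic carbon. The other is a 2.0-fold higher number from compound 1 to compound 2 (0.30 log units; within the scatter), with 3,4-difluorophenyl in place of 4-methoxy-3-methylphenyl. Neither compound 1 nor compound 2 carries a methoxy on that carbon, and both have lower numbers than compound 3. Within the data shown here, no measured compound has hydrogen there, so the data do not show its effect directly.

A lower number in this assay is therefore expected, though the drop may fall short of the full size of the large step. The expected change is a 6.7-fold lower number from compound 3 to compound 4 (0.82 log units; beyond the scatter). For compound 4 the estimated value is 300 nM, with an expected range from 80 nM to 1200 nM.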

Compound 4, concentration for 50% growth inhibition: 800 nM
Estimate against measurement, compound 4: 2.7-fold (0.43 log units) below, within the range that was stated.
By their numbers in this assay, from the lowest: compounds 1 and 2 (each within the scatter of the next); then compound 4; then compound 3.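

In this assay, hydrogen in place of methoxy on this aromatic carbon gives a 2.5-fold lower number from compound 3 to compound 4 (0.40 log units; beyond the scatter), so losing the methoxy lowers the number, but only modestly. Hydrogen is not the best of the groups seen on this carbon, since hydrogen in place of methyl gives an 8.0-fold higher number from compound 1 to compound 4 (0.90 log units; beyond the scatter); across these three compounds the order runs from methyl, with the lowest number, through hydrogen to methoxy, with the highest, so the result depends on which group sits here and not merely on whether the carbon carries one. The bare 4-methoxyphenyl ring also falls short of the 3,4-difluorophenyl ring on the double-bonded ring carbon, as 4-methoxyphenyl in place of 3,4-difluorophenyl gives a 4.0-fold higher number from compound 2 to compound 4 (0.60 log units; beyond the scatter) while the rest of the molecule stays the same.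

Nothing measured on these compounds explains why the numbers differ. Going by these compounds, it also remains open where an ethyl group, a chlorine atom or a hydroxyl group on this aromatic carbon would fall relative to methyl, hydrogen and methoxy.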